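The source may hold more compounds than are shown below. What is called first, only, known or untested is meant among the compounds shown, and "the series" means these compounds.

Measured compounds:
compound 1, `CCN(CC)Cc1c[nH]c2ccc(F)cc12`, in an assay on isolated protein for inhibition of Myeloperoxidase (Homo sapiens); on this read-out higher numbers stand for weaker inhibition and lower numbers for stronger inhibition: > 1000 nM
compound 2, `CN1CCN(Cc2c[nH]c3ccc(F)cc23)CC1`, in this assay: > 1000 nM

Compound 1 gives only a limit in this assay, > 1000 nM, so its true number is not known. Compound 2 likewise gives only a limit, > 1000 nM. Both values sit at the limit of > 1000 nM in this assay, at which 2 of the 2 values shown sit, so the two compounds cannot be told apart, and neither can be called stronger or weaker. Compound 3, `CNCCCc1c[nH]c2ccc(F)cc12`, has not been measured. It differs from compound 1 in one place: 2-(methylamino)ethyl in place of diethylamino on a saturated chain carbon bound to an aromatic carbon. Among the compounds with values here, no measured step between two compounds exists here to guide the expectation, and the shared core with a small amine side chain has so far only reached the limit. The step in this assay is therefore expected to be small, in no clear direction, probably within the scatter. For compound 3 the estimate is 2000 nM, between 500 nM and 8000 nM, most likely again only a limit.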

Compound 3, half-maximal inhibitory concentration: 26 nM
The estimate for compound 3 lay 77-fold (1.89 log units) above the measured number; the measured number lies below the stated range.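

In this assay, the saturated chain carbon bound to an aromatic carbon proves to be a place where the attached group matters greatly: swapping diethylamino for 2-(methylamino)ethyl gives an at least 38-fold lower number from compound 1 to compound 3 (1.58 log units; beyond the scatter). The earlier compounds could not show this, as compound 3 is the only one shown that gets past the limit: the limit of > 1000 nM in this assay, at which 2 of the 3 values shown sit. The entering group carries a hydrogen-bond donor where diethylamino has none, and it also differs in its heavy atoms, so this single step does not reveal which difference counts.

Going by these compounds, it remains open whether the hydrogen on the nitrogen is what matters, which a dimethylamino group on the same chain could test. A primary amine or a longer chain would show how much room this side chain leaves for change.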